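Taking the trifluoromethyl off compound 1

This account rests on a few compounds, and the source may have more. Where it says the series, first, only, none or still open, it means among the compounds named here.

In a functional assay on SNB-19 cells (Homo sapiens) for inhibition, read by sulforhodamine B assay, with a stated time of 48 h (a lower number here means a stronger inhibitor of growth, a higher number a weaker inhibitor of growth), compound 1 `COc1cc(-c2nn(-c3cccc(NC(=O)c4cccc(C(F)(F)F)c4)c3)cc2-c2ccncc2)ccc1Cl` gives 2460 nM, the highest of three measured numbers. Compound 2 `COc1cc(-c2nn(-c3cccc(NC(=O)Nc4ccc(Cl)c(Cl)c4)c3)cc2-c2ccncc2)ccc1Cl` gives 1720 nM, and compound 3 `COc1cc(-c2nn(-c3cccc(NC(=O)Nc4cccc(C(F)(F)F)c4)c3)cc2-c2ccncc2)ccc1Cl` gives 981 nM. Both differ from compound 1 on the carbonyl carbon, as a 1.4-fold lower number from compound 1 to compound 2 (0.16 log units; within the scatter) and a 2.5-fold lower number from compound 1 to compound 3 (0.40 log units; beyond the scatter) show.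

Compound 4 `COc1cc(-c2nn(-c3cccc(NC(=O)c4ccccc4)c3)cc2-c2ccncc2)ccc1Cl` instead has hydrogen in place of trifluoromethyl on an aromatic carbon. Going by the values given here, no measured step removes this group outright. The closest one exchanges 3,4-dichlorophenyl for 3-(trifluoromethyl)phenyl, and it is small: a 1.8-fold lower number from compound 2 to compound 3 (0.24 log units; within the scatter). A slightly higher number is therefore expected, with no clear shift beyond the scatter. The expected step is a 1.2-fold higher number from compound 1 to compound 4 (0.09 log units; within the scatter). For compound 4, the estimate is 3000 nM, within a range of 1200 nM to 7500 nM.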

Compound 4, concentration for 50% growth inhibition: 860 nM
Compound 4: the middle estimate sits 3.5-fold (0.54 log units) above what was measured; measured number outside the range, below it.
By their numbers in this assay, from the lowest: compounds 4, 3, 2 and 1 (each within the scatter of the next, the first and the last beyond it).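

In this assay the trifluoromethyl on this aromatic carbon proves dispensable: hydrogen there gives a 2.9-fold lower number from compound 1 to compound 4 (0.46 log units; beyond the scatter) and so a stronger inhibitor of growth. The plain benzoyl group also holds its own against the two compounds with a substituted phenylamino group on the carbonyl carbon, since a 1.1-fold lower number from compound 3 to compound 4 (0.06 log units; within the scatter) and a 2.0-fold lower number from compound 2 to compound 4 (0.30 log units; within the scatter) leave them level. Nothing measured here says why removing the group moves the number this way.

As far as these compounds go, whether a fluorine, a methoxy group, an amine or a carboxylic acid on this carbon would keep that strength remains open.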